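This account rests on a few compounds, and the source may have more. Where it says the series, first, only, none or still open, it means among the compounds named here.

Going by the values given here, compound 1 `CCn1c(-c2cnc(C)nc2)nc2c(N[C@H]3CCN(C(=O)C4CC(F)(F)C4)C3)ncnc21` is one of three compounds measured in a physicochemical assay for lipophilicity, read by HPLC; a lower number here means a more polar compound, a higher number a more lipophilic compound. In this assay compound 1 gives 1.5, the second highest of the three numbers. Compound 3 `CCn1c(-c2cnc(C)nc2)nc2c(O[C@H]3CCN(C(=O)C4CCC4)C3)ncnc21` gives 1.3 in this assay, a number within the usual scatter of that of compound 1, so the two cannot be told apart on this measurement. Compound 2 `CCn1c(-c2ccc(C(F)(F)F)nc2)nc2c(O[C@H]3CCN(C(=O)c4cocn4)C3)ncnc21` gives 2 in this assay, a number that stands beyond the scatter above compound 1. Among the compounds with values here, no pair among the three measured compounds differs in a single place, so no clean single step between measured compounds is available.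

Compound 4 `CCn1c(-c2cnc(C)nc2)nc2c(N[C@H]3CCN(C(=O)C4CC4)C3)ncnc21` has not yet been measured in this assay. It differs from compound 1 in one place: cyclopropyl in place of 3,3-difluorocyclobutyl on a carbonyl carbon. The group that leaves carries two fluorines on a four-membered ring; the group that enters is a three-membered ring of carbon only, three heavy atoms in place of six. Within the data shown here, with no measured single-point step to lean on, the expectation must rest on this count alone. For compound 4 a modest downward step is expected, a number 0.40 log units lower from compound 1 to compound 4 (beyond the scatter), small enough that it may not clear the scatter. The estimate for compound 4 in this assay is 1.1, with a range from 0.7 to 1.5.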

Compound 4, distribution coefficient: 0.8
For compound 4 the middle estimate is 0.30 log units above the measured one, within the range that was stated.
By their numbers in this assay, from the lowest: compound 4; then compounds 3 and 1 (each within the scatter of the next); then compound 2.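

In this assay the group on the carbonyl carbon, whose other neighbour is the amide-type nitrogen in a ring, proves able to move the number on its own: cyclopropyl in place of 3,3-difluorocyclobutyl gives a number 0.70 log units lower from compound 1 to compound 4 (beyond the scatter) with the rest of the structure held the same. Going by these compounds alone, this is the first reading in the set that isolates a single place, as the earlier compounds differed from one another in more than one place at once and could not tie any gap to this position. Within the data shown here, no measurement accompanying the step bears on its origin, so the compounds show only its size and direction.

On these data alone, the step changes the ring size and removes the two fluorines together, so how much of it belongs to each remains open. Also open, as far as these compounds go, is how the number would read with a cyclopentyl ring, an open chain such as isopropyl, or an amine-bearing group such as dimethylaminomethyl on the same carbonyl carbon, and whether the step would hold its size on a different core.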